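A few compounds are considered here, and "the series" means these few. Any claim that something is new, unique, unknown or untested is made for them only; others in the source may bear on it.

Measured so far in an assay on BTI cells for inhibition of Amine oxidase [flavin-containing] A (Homo sapiens), read by fluorescence, with a stated time of 20 min, tested at 1 uM; on this read-out higher numbers stand for more inhibition at the one concentration tested (going by the name of the read-out) and lower numbers for less inhibition:

Compound 1 `COc1cccc2c1OCC(C)(C)C2N` gives -0.7%.
Compound 2 `CC1(C)COc2ccccc2C1N` gives -3.8%.
Compound 3 `COc1cccc2c1C(=O)C(C)(C)CO2` gives 12.1%.

Compound 3 stands highest of the three numbers in this assay. Its nearest neighbour on the numbers is compound 1, a difference beyond the scatter, and compound 2 lies furthest from it, also beyond the scatter. For the measured compounds named here, no single-place step is counted between compound 3 and either of these two, so only the bare values are compared here.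

The unmeasured compound 4 `CC1(C)COc2ccccc2C1=O` is reached from compound 3 by one change: hydrogen in place of methoxy on an aromatic carbon.

Going by the values given here, the one measured step that bears on this change is a number 3.1 percentage points lower from compound 1 to compound 2 (within the scatter), the same exchange of hydrogen for methoxy on an aromatic carbon within the shared core, carried out on a different pair. That step stayed within the scatter. On this single precedent, the same change applied to compound 3 is expected to move this assay little, if at all, with a slight lean downward; the step from compound 3 to compound 4 is estimated at a number 4.1 percentage points lower from compound 3 to compound 4 (within the scatter). Compound 4 is therefore expected to give about 8% in this assay, with a range from -4% to 18%.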

Compound 4, a percentage reported as inhibition, at one concentration (the size of the read-out at that concentration, not a potency): 9.7%
The estimate for compound 4 lay 1.7 percentage points below the measured number; measured number inside the range.
By their numbers in this assay, from the lowest: compounds 2 and 1 (each within the scatter of the next); then compounds 4 and 3 (each within the scatter of the next).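

In this assay, hydrogen in place of methoxy on the aromatic carbon gives a number 2.4 percentage points lower from compound 3 to compound 4 (within the scatter), so this change now has a second reading, on a core carrying a carbonyl where the first pair carried an amine. The change reads much the same on both cores: the same change on two cores in this assay, a number 3.1 percentage points lower (within the scatter) from compound 1 to compound 2 and a number 2.4 percentage points lower (within the scatter) from compound 3 to compound 4, 0.7 percentage points apart, within the scatter of two such steps With both steps within the scatter, methoxy at this place, ortho to a fused ring and meta to a fused ring, is not shown to matter on either core in this assay, and the result holds whether the core bears the amine or the carbonyl.

The compounds shown leave open whether a hydroxy group, a chlorine or a longer chain such as ethoxy at this place would move the number beyond the scatter, since only methoxy and hydrogen appear there. All of these readings also come from a single concentration, so they leave open whether a difference in potency lies behind steps this small.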